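Compound 3: a swap starting from the assay limit

The source may report more compounds than this note shows. Statements on the series, on what has been measured and on what is new or still open speak of the compounds shown alone.

Compound 1 `N=c1c2c(-c3ccccc3)cn(Cc3ccccc3)c2ncn1CCO` | > 20000 nM
Compound 2 `N=c1c2c(-c3ccccc3)cn(Cc3ccccc3)c2ncn1Cc1ccco1` | > 20000 nM
Compound 3 `N=c1c2c(-c3ccccc3)cn(Cc3ccccc3)c2ncn1C1CCOCC1` | not yet measured

In a functional assay on PC-3M cells (Homo sapiens) for antiproliferative activity, read by microscopy, with a stated time of 24 h (a lower number here means a stronger inhibitor, a higher number a weaker inhibitor), compound 2 gives > 20000 nM as a limit and not a number. Compound 1 likewise gives > 20000 nM as a limit. All that has been measured is the limit of > 20000 nM in this assay, at which 2 of the 2 values shown sit, and that bears only loosely on the next change. Compound 3 has oxan-4-yl in place of (furan-2-yl)methyl on an aromatic nitrogen, and the difference is oxan-4-yl in place of (furan-2-yl)methyl on an aromatic nitrogen in full. No direction is favoured, since a step that the two limits leave unreadable from compound 1 to compound 2 gives no size to carry over. The estimated change is a number no higher from compound 2 to compound 3 (the limit leaves the size open) and none beyond the usual scatter is expected. Compound 3 is estimated to give 20000 nM within an expected range of 7000 nM to 40000 nM in this assay. It may again turn out to be only a limit.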

Compound 3, half-maximal inhibitory concentration: > 20000 nM
Compound 3: only a limit was reported; the forecaster's own chance of this, stated with the estimate: 75%; the middle value sits exactly at the limit.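

No step can be read among compound 1, compound 2 and compound 3, since each gives only a limit: the limit of > 20000 nM in this assay, at which 3 of the 3 values shown sit.

The compounds shown leave open how the three groups on the aromatic nitrogen rank against one another.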